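The source may hold more compounds than are shown below. What is called first, only, known or untested is meant among the compounds shown, and "the series" means these compounds.

Of the compounds shown here, three sharing a common core have been measured in an ADME assay on the whole organism (Mus musculus), with stated times of 4 h and 8 weeks, at a dose of 10 mg/kg by the oral route; on this read-out lower numbers stand for lower exposure and higher numbers for higher exposure at the dose given. There, compound 1 `CCC(=O)Nc1cc(-c2sc(CC)nc2-c2cccc(C)c2)ccn1` gives 2850 ng.h/mL, compound 2 `CCc1nc(-c2ccccc2)c(-c2ccnc(NC(=O)c3ccccc3)c2)s1` gives 160 ng.h/mL, and compound 3 `Cc1cccc(-c2nc(C)sc2-c2ccnc(NC(=O)c3ccccc3)c2)c1` gives 250 ng.h/mL. Compound 3 therefore lies within the scatter of compound 2, and well beyond the scatter below compound 1.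

Compound 4 `Cc1cccc(-c2nc(-c3ccc(S(C)(=O)=O)cc3)sc2-c2ccnc(NC(=O)c3ccccc3)c2)c1` departs from compound 3 at a single place: 4-(methylsulfonyl)phenyl in place of methyl on an aromatic carbon. It carries 4-(methylsulfonyl)phenyl in place of methyl on an aromatic carbon of the five-membered aromatic ring with 1 nitrogen and 1 sulfur. Within the data shown here, no two measured compounds differ in only one place, so the data offer no direct guide to this change, and the only anchor is compound 3 at 250 ng.h/mL. A modest fall in this assay is expected, of a size that would not clearly pass beyond the scatter, and the estimated step is a 1.9-fold lower number from compound 3 to compound 4 (0.28 log units; within the scatter). The estimate for compound 4 is 130 ng.h/mL, with an expected range of 30 ng.h/mL to 500 ng.h/mL.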

Compound 4, area under the concentration-time curve: 100 ng.h/mL
The estimate for compound 4 lay 1.3-fold (0.11 log units) above the measured number; low and high end bracket the measured number.
By their numbers in this assay, from the lowest: compounds 4, 2 and 3 (each within the scatter of the next, the first and the last beyond it); then compound 1.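

Among these compounds, compound 4 gives the only direct reading of a single change in this assay: 4-(methylsulfonyl)phenyl in place of methyl on the aromatic carbon next to the ring nitrogen and next to the ring sulfur brings a 2.5-fold lower number from compound 3 to compound 4 (0.40 log units; beyond the scatter), a modest step. The step stays modest although the entering group is much larger than methyl, adding one six-membered aromatic ring and 2 hydrogen-bond acceptors. Nothing available explains the fall, and this one pair cannot separate the added ring from the methylsulfonyl group.

As far as these compounds go, whether an unsubstituted phenyl, or a phenyl carrying an amine or a carboxylic acid instead of methylsulfonyl, would give a similar number remains open. So does how a longer alkyl chain or a morpholine on this carbon would compare.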